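Pyridin-3-yl in place of 1H-pyrazol-1-yl in compound 2

A few compounds are considered here, and "the series" means these few. Any claim that something is new, unique, unknown or untested is made for them only; others in the source may bear on it.

Within the data shown here, in a functional assay on PC-3 cells (Homo sapiens) for antiproliferative activity, read by CCK-8 assay, with a stated time of 6 days (a lower number here means a stronger inhibitor, a higher number a weaker inhibitor), compound 1 `CCN(c1ccc(C#N)c(Cl)c1)c1cc(-n2cnc3ccccc32)ccc1C` gives 8160 nM and compound 2 `CCN(c1ccc(C#N)c(Cl)c1)c1cc(-n2cccn2)ccc1C` gives 15700 nM as the only two numbers so far. Compound 2 therefore stands within the scatter of compound 1. Among the measured compounds shown here, the single measured step, a 1.9-fold higher number from compound 1 to compound 2 (0.28 log units; within the scatter), came with 1H-pyrazol-1-yl in place of 1H-benzimidazol-1-yl on an aromatic carbon.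

Compound 3 `CCN(c1ccc(C#N)c(Cl)c1)c1cc(-c2cccnc2)ccc1C` carries pyridin-3-yl in place of 1H-pyrazol-1-yl on the same aromatic carbon, meta to a large group and para to a methyl group (pyridin-3-yl in place of 1H-pyrazol-1-yl on an aromatic carbon). This is again an exchange of one aromatic ring for another, and one step is a thin guide. With a 1.9-fold higher number from compound 1 to compound 2 (0.28 log units; within the scatter) as that guide, no change beyond the scatter is expected in this assay, in either direction. The expected step is a 1.4-fold lower number from compound 2 to compound 3 (0.15 log units; within the scatter) and it remains small. For compound 3 the estimate is 11000 nM, with an expected range of 4500 nM to 27000 nM as the likely span.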

Compound 3, half-maximal inhibitory concentration: 11000 nM
Estimate against measurement, compound 3: no gap at the digits printed; the range from low to high includes it.
By their numbers in this assay, from the lowest: compounds 1, 3 and 2 (each within the scatter of the next).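

At this place, on an aromatic carbon meta to a large group and para to a methyl group, pyridin-3-yl gives a 1.4-fold lower number from compound 2 to compound 3 (0.15 log units; within the scatter) in this assay and, against 1H-benzimidazol-1-yl, a 1.3-fold higher number from compound 1 to compound 3 (0.13 log units; within the scatter) in the same read-out. A six-membered aromatic ring with 1 hetero atom therefore joins the five-membered pyrazolyl and the benzimidazolyl with no separation among the three, so neither ring size nor hetero atom count tracks the number across compounds 1, 2 and 3. No measurement bearing on why these values lie so close is at hand.

Open, from the compounds shown here alone, is whether a non-aromatic group at this place, such as an amine, a carboxylic acid or a longer alkyl chain, would move the number beyond the scatter. Also open, going by these compounds, is whether a methoxy group or an amine on the pyridin-3-yl ring itself would do so.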